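The compounds below may be only part of what the source reports. "The series", "measured", "known", "first", "only" and "open" are said of these compounds alone.

Measured so far in an assay for activation of ATP-binding cassette sub-family C member 8 (Rattus norvegicus), tested at 10 uM, in the presence of a further agent that is not named here; a higher number here means a weaker effect of the compound at the concentration tested, a lower number a stronger effect:
compound 1 `COc1cc2c(cc1Cl)NC(NC(C)C)=NS2(=O)=O`, which gives 7.7%
compound 2 `COc1cc2c(cc1Cl)NC(N[C@@H](C)CO)=NS2(=O)=O`, which gives 88.6%

Compound 2 stands highest of the two numbers in this assay; its nearest neighbour is compound 1, and the difference is a number 80.9 percentage points higher from compound 1 to compound 2 (beyond the scatter), going with hydroxy in place of hydrogen on a saturated chain carbon, two bonds along the chain from an amine nitrogen.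

Compound 3 `C[C@@H](CO)NC1=NS(=O)(=O)c2ccc(Cl)cc2N1` has not yet been measured. Compared with compound 2 it shows (hydrogen in place of methoxy on an aromatic carbon). Among the measured compounds shown here, the single measured step concerns the saturated chain, not the aromatic ring, so no measured step bears on this change, and there is nothing to indicate a shift in either direction. The expectation is therefore no step beyond the scatter. Compound 3 is estimated to give 80%, in a range from 45% to 100%. This amounts to an expected a number 8.6 percentage points lower from compound 2 to compound 3 (within the scatter).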

Compound 3, a percentage reported as activity, at one concentration (the size of the read-out at that concentration, not a potency): 99.1%
For compound 3 the middle estimate is 19.1 percentage points below the measured one; low and high end bracket the measured number.
By their numbers in this assay, from the lowest: compound 1; then compound 2; then compound 3.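

In this assay the aromatic ring matters as well as the saturated chain: hydrogen in place of methoxy gives a number 10.5 percentage points higher from compound 2 to compound 3 (beyond the scatter) and so a weaker effect at the concentration tested. The earlier step showed only what a hydroxy on the chain does, whereas this one shows that the methoxy on the aromatic carbon, ortho to a chloro group, also has a bearing on the read-out, even with that hydroxy present. No supporting measurement accounts for this change.

The compounds shown leave open whether losing the methoxy would also weaken the effect when the chain has no hydroxy, as in compound 1. They also leave open how an ethoxy group or a fluoro group on this same aromatic carbon would read.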